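The source may report more compounds than this note shows. Statements on the series, on what has been measured and on what is new or still open speak of the compounds shown alone.

Three compounds built on one shared core differ only in the aromatic group attached to a six-membered ring of carbon. Compound 1 `CCC(C)(C)Cc1c[nH]c(CCc2ccc(-n3ccnn3)cc2)n1` carries a 1H-1,2,3-triazol-1-yl group, and in a functional assay on HEK293 cells for agonist activity at Bombesin receptor subtype-3 (Homo sapiens), read by luminescence and calcium flux, with a stated time of 10 min (on this read-out higher numbers stand for an effect only at larger amounts of compound and lower numbers for an effect already at smaller amounts), compound 1 gives 641 nM. Compound 2 `CCC(C)(C)Cc1c[nH]c(CCc2ccc(-c3cnsc3)cc2)n1` carries a 1,2-thiazol-4-yl group, and in this assay compound 2 gives 44 nM; the step of a 15-fold lower number from compound 1 to compound 2 (1.16 log units; beyond the scatter) is the largest among these compounds. Compound 3 `CCC(C)(C)Cc1c[nH]c(CCc2ccc(-c3cccnc3)cc2)n1` carries a pyridin-3-yl group, and in this assay compound 3 gives 131 nM, the second highest of the three numbers: the step of a 4.9-fold lower number from compound 1 to compound 3 (0.69 log units; beyond the scatter) places it well below compound 1, while the step of a 3.0-fold higher number from compound 2 to compound 3 (0.47 log units; beyond the scatter) places it above compound 2.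

Compound 4 `CCC(C)(C)Cc1c[nH]c(CCc2ccc(-c3ccns3)cc2)n1` has not yet been measured. Its change is 1,2-thiazol-5-yl in place of pyridin-3-yl on an aromatic carbon. The step that bears most on it is a 3.0-fold higher number from compound 2 to compound 3 (0.47 log units; beyond the scatter), because compound 2 also carries a 1,2-thiazole ring, there as 1,2-thiazol-4-yl rather than 1,2-thiazol-5-yl. Reversing that step in part seems the likeliest outcome, with some doubt since the ring is joined differently. For compound 4 this expectation means a step of a 2.2-fold lower number from compound 3 to compound 4 (0.34 log units; beyond the scatter). The estimate for compound 4 in this assay is 60 nM, expected to lie between 20 nM and 200 nM.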

Compound 4, half-maximal effective concentration: 63 nM
Compound 4: the middle estimate sits 1.1-fold (0.02 log units) below what was measured; low and high end bracket the measured number.
By their numbers in this assay, from the lowest: compounds 2 and 4 (each within the scatter of the next); then compound 3; then compound 1.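

Moving the join of the 1,2-thiazole ring from 1,2-thiazol-4-yl to 1,2-thiazol-5-yl at this place, para to a large group, gives no difference that can be told apart in this assay, with a 1.4-fold higher number from compound 2 to compound 4 (0.16 log units; within the scatter) here. The 1,2-thiazol-5-yl group is also separated from the six-membered pyridin-3-yl, with a 2.1-fold lower number from compound 3 to compound 4 (0.32 log units; beyond the scatter) as that step, and from the 1H-1,2,3-triazol-1-yl group, with a 10-fold lower number from compound 1 to compound 4 (1.01 log units; beyond the scatter) as that step, so both 1,2-thiazole compounds now give lower numbers than compound 3 and compound 1. Nothing available accounts for these differences.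

The compounds shown leave open whether the ring nitrogen of the 1,2-thiazole is needed, which a thiophene ring, with sulfur and no nitrogen, would address. As far as these compounds go, how a plain phenyl ring or a carboxylic acid would behave at this place also remains open.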